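The source may report more compounds than this note shows. Statements on the series, on what has been measured and on what is new or still open speak of the compounds shown alone.

Compound 1 `Cc1ccc2c(=O)c(CSC(=S)N3CCCCC3)coc2c1` carries a thiocarbonyl bearing a piperidin-1-yl group. In a functional assay on HEp-2 cells (Homo sapiens) for antiproliferative activity, read by MTT assay, with a stated time of 72 h (on this read-out higher numbers stand for weaker inhibition and lower numbers for stronger inhibition), compound 1 gives 900 nM. Two related compounds give a sense of the range. Going by the values given here, compound 2 `CC(C)N(C(=S)SCc1oc2ccccc2c(=O)c1Cl)C(C)C` gives 20000 nM, and compound 3 `CC(C)N(C(=S)SCc1cc(=O)c2ccccc2o1)C(C)C` gives 13600 nM; the move from compound 2 to compound 3 is a 1.5-fold lower number from compound 2 to compound 3 (0.17 log units; within the scatter), the only single-point step among the measured set. Compound 1 therefore stands at the lowest number of the three, well clear of both compound 2 and compound 3, and on this read-out that makes compound 1 the strongest inhibitor seen so far.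

Compound 4 `Cc1ccc2c(=O)c(CSC(=S)N3CCOCC3)coc2c1` differs from compound 1 in a single place: morpholin-4-yl in place of piperidin-1-yl on a thiocarbonyl carbon. Among the compounds with values here, none of the measured steps touches the group on the thiocarbonyl carbon, so there is no direct precedent for this exchange; the one measured step concerns a different part of the core. With nothing to show that this swap moves the number far, the expected step from compound 1 to compound 4 is a 1.7-fold higher number from compound 1 to compound 4 (0.22 log units; within the scatter). On that basis compound 4 is estimated in this assay at 1500 nM, with a range from 500 nM to 5000 nM, the width reflecting the absence of any guiding step.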

Compound 4, half-maximal inhibitory concentration: 4000 nM
The estimate for compound 4 lay 2.7-fold (0.43 log units) below the measured number, and the stated range covers the measured number.
By their numbers in this assay, from the lowest: compound 1; then compound 4; then compounds 3 and 2 (each within the scatter of the next).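

In this assay, going by these compounds alone, the group on the thiocarbonyl carbon proves to matter: morpholin-4-yl in place of piperidin-1-yl gives a 4.4-fold higher number from compound 1 to compound 4 (0.65 log units; beyond the scatter) and so lies beyond the scatter, whereas the only earlier step, hydrogen in place of chloro on an aromatic carbon, stayed within it. The change itself is small on paper, since both groups are six-membered non-aromatic rings with the same number of heavy atoms, and the entering ring differs by holding an oxygen in place of one carbon and by counting one hydrogen-bond acceptor where the leaving ring counts none. Nothing measured here explains why this exchange raises the number, so the step stands as an observation without a known cause.

Still open, as far as these compounds go, is how other groups on the thiocarbonyl carbon would behave, such as the five-membered pyrrolidin-1-yl, the larger azepan-1-yl, or a 4-methylpiperazin-1-yl ring, and so whether piperidin-1-yl is a particularly good choice or merely the better of these two. Also open, from the compounds shown here alone, is whether the same exchange would move the number by a similar amount on a different core, for instance one carrying a chloro or lacking the methyl group.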